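A Methoxy Swap at the Edge of the Assay

The compounds below may be only part of what the source reports. "The series", "measured", "known", "first", "only" and "open" are said of these compounds alone.

In a functional assay on HEK293 cells (Homo sapiens) for antiproliferative activity, read by MTT assay, with a stated time of 72 h (a lower number here means a stronger inhibitor of growth, a higher number a weaker inhibitor of growth), compound 3 (`Cc1ccc(Cl)c(-n2nnc(C(=O)Nc3ccc(SC#N)cc3)c2C)c1`) gives > 100000 nM, which is a limit and not a number. Compound 1 (`Cc1c(C(=O)Nc2ccc(SC#N)cc2)nnn1-c1ccc(C(C)C)cc1`) gives > 100000 nM, which is also a limit. Among the compounds with values here, compound 2 (`Cc1ccc(Cl)cc1-n1nnc(C(=O)Nc2ccc(SC#N)cc2)c1C`) gives 91200 nM, the only true number so far. The picture is dominated by the limit of > 100000 nM in this assay, at which 2 of the 3 values shown sit.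

Going on to compound 4 (`COc1cccc(-n2nnc(C(=O)Nc3ccc(SC#N)cc3)c2C)c1`), the change is 3-methoxyphenyl in place of 2-chloro-5-methylphenyl on an aromatic nitrogen. The group on the aromatic nitrogen is replaced, and the new group brings 1 hydrogen-bond acceptor.

Three measured steps at this same place bear on it: an at least 1.0-fold lower number from compound 1 to compound 2 (0.04 log units; that floor lies within the scatter), an at least 1.0-fold higher number from compound 2 to compound 3 (0.04 log units; that floor lies within the scatter) and a step that the two limits leave unreadable from compound 1 to compound 3. None of them shows a readable change beyond the scatter, so no step beyond the scatter is expected in this assay, in either direction. The expected size is a number no higher from compound 3 to compound 4 (the limit leaves the size open). The expected result may well be another limit. The estimate for compound 4 is 100000 nM, with an expected range from 45000 nM to 200000 nM.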

Compound 4, concentration for 50% growth inhibition: > 100000 nM
Compound 4 ended at the assay's limit; the forecaster's own chance of this, stated with the estimate: 65%; the middle value lies on the limit itself.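

In this assay, compound 4 gives > 100000 nM, which is a limit of the assay, so the hydrogen-bond acceptor brought by the 3-methoxyphenyl group does not yield a readable value at this position. Within the data shown here, the only readable comparison is an at least 1.0-fold higher number from compound 2 to compound 4 (0.04 log units; that floor lies within the scatter), while the steps from compound 1 and compound 3 to compound 4 cannot be read, so this change shows no movement beyond the scatter. With an oxygen-bearing group now tested on the aromatic nitrogen alongside the chlorine-bearing and purely carbon-substituted groups, the series looks flatter still: the limit of > 100000 nM in this assay, at which 3 of the 4 values shown sit.

From the compounds shown here alone, it remains open whether an amine or a carboxylic acid on this phenyl ring would give a value clearly inside the range of the assay. Also open, going by these compounds, is whether any group at this position can shift the result well beyond the scatter.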